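The source may hold more compounds than are shown below. What is called first, only, known or untested is meant among the compounds shown, and "the series" means these compounds.

In an ADME assay on Vero cells (Chlorocebus sabaeus) for cytotoxicity, read by MTT assay, with a stated time of 72 h (on this read-out lower numbers stand for an effect already at smaller amounts and higher numbers for an effect only at larger amounts of compound), compound 1 (`O=C(Nc1nc(-c2ccccn2)cs1)c1cccc(OCc2ccccc2)c1`) gives 14400 nM and compound 3 (`O=C(Nc1nc(-c2ccccn2)cs1)c1cccc(Br)c1`) gives 16100 nM on the same shared core. Compound 2 (`O=C(Nc1nc(-c2ccccn2)cs1)c1cccc([N+](=O)[O-])c1`) has the entry "not determined" (no result reported) and so adds no number. Compound 3 therefore stands level with compound 1 within the scatter, and these two values are all there is to compare.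

Compound 4 (`O=C(Nc1nc(-c2ccccn2)cs1)c1cccnc1Cl`) is still unmeasured. It carries 2-chloropyridin-3-yl in place of 3-bromophenyl on a carbonyl carbon, so a ring of carbon only gives way to a ring with a hetero atom. Among the measured compounds shown here, only one measured step bears on this, and only loosely: a 1.1-fold higher number from compound 1 to compound 3 (0.05 log units; within the scatter) with bromo in place of benzyloxy on an aromatic carbon, and it stays within the scatter. For the measured compounds named here, no measured compound has a ring with a hetero atom at this place, so nothing shows a direction.

In this assay the expected result is therefore no step beyond the scatter, with a 1.1-fold higher number from compound 3 to compound 4 (0.05 log units; within the scatter) as the estimate. For compound 4 the estimated value is 18000 nM with an expected range from 7000 nM to 45000 nM as the likely span.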

Compound 4, half-maximal effective concentration: 1900 nM
Estimate against measurement, compound 4: 9.5-fold (0.98 log units) above; the measured number lies below the stated range.
By their numbers in this assay, from the lowest: compound 4; then compounds 1 and 3 (each within the scatter of the next).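

In this assay, among the compounds shown here, 2-chloropyridin-3-yl in place of 3-bromophenyl on the carbonyl carbon gives an 8.5-fold lower number from compound 3 to compound 4 (0.93 log units; beyond the scatter) and is the first step in this small set to lie beyond the scatter, whereas bromo in place of benzyloxy stayed within it. So the group at this place can shift the number, here towards an effect on the cells at smaller amounts of compound. The change replaces a ring of carbon only with a ring holding a hetero atom and also exchanges bromine for chlorine, and no measurement here explains the shift.

Whether the ring nitrogen or the chlorine accounts for the step stays open, and a plain pyridin-3-yl or a 3-chlorophenyl at this place would separate the two. On these data alone, how an amine or a carboxylic acid on this ring would act also remains open.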